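This account rests on a few compounds, and the source may have more. Where it says the series, first, only, none or still open, it means among the compounds named here.

Compound 1 `COc1ccc(-c2nc3cc(F)ccc3s2)cc1F` gives 640 nM in a functional assay on MDA-MB-468 cells (Homo sapiens) for antiproliferative activity; a higher number here means a weaker inhibitor of growth, a lower number a stronger inhibitor of growth. Compound 2 `COc1ccc(-c2nc3cc(F)ccc3s2)cc1Br` gives 420 nM in this assay, the lowest of the two numbers in hand, with compound 1 nearest and within the scatter; the step of a 1.5-fold lower number from compound 1 to compound 2 (0.18 log units; within the scatter) is small. Compound 3 `COc1ccc(-c2nc3cc(F)ccc3s2)cc1O` is not yet measured. The change from compound 2 to compound 3 is hydroxy in place of bromo on an aromatic carbon. For the measured compounds named here, the only step available, a 1.5-fold lower number from compound 1 to compound 2 (0.18 log units; within the scatter), exchanges one halogen for another and does not bear directly on hydroxy in place of bromo; no step for such a change exists. For compound 3 the expected result in this assay is 600 nM, between 200 nM and 2000 nM. This estimate means a step of a 1.4-fold higher number from compound 2 to compound 3 (0.15 log units; within the scatter) expected to stay within the scatter.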

Compound 3, concentration for 50% growth inhibition: 50 nM
Compound 3: the middle estimate sits 12-fold (1.08 log units) above what was measured; measured number outside the range, below it.
By their numbers in this assay, from the lowest: compound 3; then compounds 2 and 1 (each within the scatter of the next).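

At this position, ortho to a methoxy group, the two halogens stay within the scatter of each other in this assay and so showed no sensitivity to substitution. Hydroxy gives an 8.4-fold lower number from compound 2 to compound 3 (0.92 log units; beyond the scatter) and, in place of fluoro, a 13-fold lower number from compound 1 to compound 3 (1.11 log units; beyond the scatter) so the position does respond, and the response comes with the one entering group that carries a hydrogen-bond donor. Nothing available explains this difference. Open, on these data alone, is whether an amine at this position would track hydroxy or the halogens, and whether a second methoxy group would retain the lower number.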